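Aryl Swap on the Amide and MT4 Cytotoxicity

The source may report more compounds than this note shows. Statements on the series, on what has been measured and on what is new or still open speak of the compounds shown alone.

Compound 1 `Cc1cc(C#N)cc(C)c1Oc1ccnc(S(=O)(=O)CC(=O)Nc2ccc(Br)cc2)n1`: 15600 nM
Compound 2 `Cc1cc(C#N)cc(C)c1Oc1ccnc(S(=O)(=O)CC(=O)Nc2ccc(C#N)cc2F)n1`: > 268000 nM

In an ADME assay on MT4 cells (Homo sapiens) for cytotoxicity, read by MTT assay, with a stated time of 4 days (on this read-out higher numbers stand for lower toxicity in this test and lower numbers for higher toxicity in this test), compound 1 gives 15600 nM. For compound 2 the assay reports only a limit, > 268000 nM. From the compounds shown here alone, compound 2 therefore stands at the limit of > 268000 nM in this assay, at which 1 of the 2 values shown sits, so its true number is unknown. Among the measured compounds shown here, the one measured step, an at least 17-fold higher number from compound 1 to compound 2 (1.23 log units; beyond the scatter), shows that exchanging the aryl on the amide-type nitrogen can move this assay strongly. Compound 3 `Cc1cc(C#N)cc(C)c1Oc1ccnc(S(=O)(=O)CC(=O)Nc2cccc([N+](=O)[O-])c2)n1` differs from compound 2 by 3-nitrophenyl in place of 4-cyano-2-fluorophenyl on an amide-type nitrogen. The same position is changed again, so a step of some size is expected, but its direction cannot be told from compound 1 and compound 2 alone. Compound 3 is estimated at 90000 nM, between 15000 nM and 300000 nM, an expected step of an at least 2.9-fold lower number from compound 2 to compound 3 (0.47 log units; beyond the scatter).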

Compound 3, half-maximal cytotoxic concentration: 23600 nM
Beside the measured number, compound 3's estimate is 3.8-fold (0.58 log units) above it; low and high end bracket the measured number.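

In this assay, 3-nitrophenyl on the amide-type nitrogen gives an at least 11-fold lower number from compound 2 to compound 3 (1.05 log units; beyond the scatter), so the high reading of 4-cyano-2-fluorophenyl does not carry over to this other aryl group. Set against 4-bromophenyl, 3-nitrophenyl gives a 1.5-fold higher number from compound 1 to compound 3 (0.18 log units; within the scatter), so these two groups cannot be told apart here. Compound 2 alone remains a limit: the limit of > 268000 nM in this assay, at which 1 of the 3 values shown sits.

The compounds shown do not separate the nitrile of 4-cyano-2-fluorophenyl from its fluorine. From the compounds shown here alone, how an aryl group carrying an amine or a carboxylic acid would read in this assay also stays open.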